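Ortho-Fluoro Added to the Benzamide of Compound 3

This account rests on a few compounds, and the source may have more. Where it says the series, first, only, none or still open, it means among the compounds named here.

Going by the values given here, compound 3 `CN1CCN(c2ccc(Nc3nc(-c4cccc(NC(=O)c5ccccc5)c4)sc3C(N)=O)cc2)CC1` gives 6360 nM in a functional assay on Raji cells (Homo sapiens) for antiproliferative activity, read by CCK-8 assay, with a stated time of 72 h (on this read-out lower numbers stand for stronger inhibition and higher numbers for weaker inhibition), the second highest of the three numbers known. Compound 2 `CN1CCN(c2ccc(Nc3nc(-c4cccc(NC(=O)c5ccc(F)cc5)c4)sc3C(N)=O)cc2)CC1` gives 2820 nM, and compound 1 `CN1CCN(c2ccc(Nc3nc(-c4cccc(NC(=O)c5ccccc5F)c4)sc3C(=O)O)cc2)CC1` gives 13900 nM. Among the compounds with values here, the one single-point step known is a 2.3-fold higher number from compound 2 to compound 3 (0.35 log units; beyond the scatter); compound 1 differs from compound 3 in two places, so its value can only be set beside that of compound 3 without a step.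

Compound 4 `CN1CCN(c2ccc(Nc3nc(-c4cccc(NC(=O)c5ccccc5F)c4)sc3C(N)=O)cc2)CC1` differs from compound 3 by fluoro in place of hydrogen on an aromatic carbon. The step from compound 2 to compound 3 bears on this, though its fluorine sits elsewhere on the same ring; read backwards it says that fluoro entering gave a modestly lower number. Compound 1 carries the same fluoro as compound 4 on a different core and gives the highest number, which warns against a firm expectation. A modest lowering is therefore expected, a 1.4-fold lower number from compound 3 to compound 4 (0.15 log units; within the scatter), in this assay. Compound 4 is estimated at 4500 nM, with a range of 1800 nM to 11000 nM.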

Compound 4, half-maximal inhibitory concentration: 3270 nM
Beside the measured number, compound 4's estimate is 1.4-fold (0.14 log units) above it; the range from low to high includes it.
By their numbers in this assay, from the lowest: compounds 2, 4 and 3 (each within the scatter of the next, the first and the last beyond it); then compound 1.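

In this assay, fluoro on this aromatic carbon, ortho to a large group, does not separate clearly from hydrogen: the result is a 1.9-fold lower number from compound 3 to compound 4 (0.29 log units; within the scatter). The 2-fluorophenyl and 4-fluorophenyl compounds also cannot be told apart, with a 1.2-fold higher number from compound 2 to compound 4 (0.06 log units; within the scatter), even though only the 4-fluorophenyl compound stands beyond the scatter from the phenyl compound. Going by these compounds alone, with 2-fluorophenyl kept, amino in place of hydroxy on a carbonyl carbon gives a 4.3-fold lower number from compound 1 to compound 4 (0.63 log units; beyond the scatter), the only new step beyond the scatter, and no measurement at hand accounts for any of these steps.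

From the compounds shown here alone, whether chloro or methoxy on this same carbon would stand apart from hydrogen remains open. Also open, going by these compounds, is whether methylamino in place of amino on the carbonyl carbon would keep the number of compound 4.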